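A few compounds are considered here, and "the series" means these few. Any claim that something is new, unique, unknown or untested is made for them only; others in the source may bear on it.

Compound 1 `O=C(NNS(=O)(=O)c1ccccc1F)c1cc(F)cc(-n2cccn2)c1` is measured in an ADME assay on microsomes from liver (Mus musculus) for metabolic stability, read by HPLC, using NADPH, with a stated time of 60 min, tested at 1 uM, in the presence of a further agent that is not named here (on this read-out higher numbers stand for fast clearance and lower numbers for slow clearance), and gives 334 uL/min. That is the highest of the two numbers shown, and its nearest neighbour is compound 2 `O=C(NNS(=O)(=O)c1ccccc1F)c1cc(F)cc(-c2ccccn2)c1`, which in this assay gives 131 uL/min; the step of a 2.5-fold lower number from compound 1 to compound 2 (0.41 log units; beyond the scatter) goes with pyridin-2-yl in place of 1H-pyrazol-1-yl on an aromatic carbon. The step now followed leads from compound 1 to compound 3 `O=C(NNS(=O)(=O)c1ccccc1F)c1cccc(-n2cccn2)c1`, where the counted difference is hydrogen in place of fluoro on an aromatic carbon. For the measured compounds named here, no measured step bears directly on this change, since the one step known alters the five-membered ring and not the fluoro, so there is no reason drawn from the data to expect a step beyond the scatter in this assay in either direction. For compound 3 the estimated result is 370 uL/min, with a range from 190 uL/min to 720 uL/min. This estimate means a step of a 1.1-fold higher number from compound 1 to compound 3 (0.04 log units; within the scatter), expected to stay inside the usual scatter.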

Compound 3, intrinsic clearance in a liver preparation (reported as CLH), per the amount of preparation that the assay uses: 178 uL/min
The estimate for compound 3 lay 2.1-fold (0.32 log units) above the measured number; measured number below the stated range.
By their numbers in this assay, from the lowest: compounds 2, 3 and 1 (each within the scatter of the next, the first and the last beyond it).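

In this assay, hydrogen in place of fluoro on this aromatic carbon, meta to a 1H-pyrazol-1-yl group, gives a 1.9-fold lower number from compound 1 to compound 3 (0.27 log units; within the scatter), so the read-out does not separate the fluoro from hydrogen at this position. Among the steps from compound 1, the one beyond the scatter remains the change at the other place, a 2.5-fold lower number from compound 1 to compound 2 (0.41 log units; beyond the scatter). Nothing at hand speaks to the origin of either step.

The compounds shown leave open how a larger group on this carbon, such as methoxy or trifluoromethyl, or a nitrile, would read in this assay. They also leave open whether hydrogen in place of fluoro would give a similar step with pyridin-2-yl in place of 1H-pyrazol-1-yl.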